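Phenylsulfanyl in place of nitrophenoxy on the shared core

The source may report more compounds than this note shows. Statements on the series, on what has been measured and on what is new or still open speak of the compounds shown alone.

In an assay for inhibition of Thromboxane-A synthase (Homo sapiens), using microsomes (on this read-out lower numbers stand for stronger inhibition and higher numbers for weaker inhibition), compound 3 `CC(C)(Oc1ccccc1[N+](=O)[O-])C1OCC(C/C=C\CCC(=O)O)C(c2cccnc2)O1` gives < 10 nM, which is a limit of the measurement and not a number (the limit of < 10 nM in this assay, at which 1 of the 3 values shown sits). Compound 1 `N#Cc1ccccc1C1OCC(C/C=C\CCC(=O)O)C(c2cccnc2)O1` gives 54 nM in this assay. Going by the values given here, compound 2 `Cc1ccc(OC(C)(C)C2OCC(C/C=C\CCC(=O)O)C(c3cccnc3)O2)cc1` gives 360 nM in this assay, and the one measured change at the same position is the step of an at least 36-fold lower number from compound 2 to compound 3 (1.55 log units; beyond the scatter). Compound 4 `CC(C)(Sc1ccccc1)C1OCC(C/C=C\CCC(=O)O)C(c2cccnc2)O1` differs from compound 3 by phenylsulfanyl in place of 2-nitrophenoxy on a saturated chain carbon bound to two saturated chain carbons and a saturated ring carbon: the nitro group that accompanied that large step is gone, the oxygen is exchanged for sulfur, and the phenyl ring remains. The step of an at least 12-fold higher number from compound 3 to compound 4 (1.07 log units; beyond the scatter) is therefore expected to be a rise in the number, back toward where compound 2 stands. Compound 4 is estimated at 120 nM, within 30 nM to 500 nM.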

Compound 4, half-maximal inhibitory concentration: 40 nM
Beside the measured number, compound 4's estimate is 3.0-fold (0.48 log units) above it, and the stated range covers the measured number.
By their numbers in this assay, from the lowest: compounds 4 and 1 (each within the scatter of the next); then compound 2. At a limit, below all of these: compound 3.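

Going by these compounds alone, without any nitro group, this saturated chain carbon still gives a 9.0-fold lower number from compound 2 to compound 4 (0.95 log units; beyond the scatter), so 2-nitrophenoxy is not the only group here that improves on 4-methylphenoxy. The step of an at least 4.0-fold higher number from compound 3 to compound 4 (0.60 log units; beyond the scatter) is only a bound, as compound 3 stands at a limit of the assay: the limit of < 10 nM in this assay, at which 1 of the 4 values shown sits.
The groups on the saturated ring carbon are not told apart by a 1.4-fold lower number from compound 1 to compound 4 (0.13 log units; within the scatter).

The change from compound 3 to compound 4 exchanges oxygen for sulfur and removes the nitro group together, and the compounds shown do not separate the two. Plain phenoxy or 2-nitrophenylsulfanyl on this carbon would separate them.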